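Methoxy on the benzyl group: a step without a precedent

A few compounds are considered here, and "the series" means these few. Any claim that something is new, unique, unknown or untested is made for them only; others in the source may bear on it.

Measured compounds:
- compound 1 `O=C(NC1CCCC1)Oc1ccc(C2=NCCS2)cc1`: 130 nM
- compound 2 `O=C(NCc1ccccc1)Oc1ccc(C2=NCCS2)cc1`: 290 nM

Both compounds were tested in an assay on cell membranes (strain Wistar) for inhibition of Fatty-acid amide hydrolase 1 (Rattus norvegicus), read by scintillation counting; on this read-out lower numbers stand for stronger inhibition and higher numbers for weaker inhibition. Compound 2 stands at the higher of the two numbers, with a 2.2-fold higher number from compound 1 to compound 2 (0.35 log units; beyond the scatter) separating it from compound 1. Compound 3 `COc1ccc(CNC(=O)Oc2ccc(C3=NCCS3)cc2)cc1` has not been measured. It differs from compound 2 by methoxy in place of hydrogen on an aromatic carbon, which read one bond further out is phenyl to 4-methoxyphenyl. Within the data shown here, only one measured step exists here, the exchange of cyclopentyl for benzyl from compound 1 to compound 2, and it does not involve a methoxy group, so it offers no direct guide. With nothing to point either way, a change close to the scatter is expected, so the estimate for compound 3 is 300 nM, within 100 nM to 900 nM, meaning an expected 1.0-fold higher number from compound 2 to compound 3 (0.01 log units; within the scatter).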

Compound 3, half-maximal inhibitory concentration: 320 nM
Compound 3: the middle estimate sits 1.1-fold (0.03 log units) below what was measured; low and high end bracket the measured number.
By their numbers in this assay, from the lowest: compound 1; then compounds 2 and 3 (each within the scatter of the next).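

In this assay the phenyl to 4-methoxyphenyl exchange gives a 1.1-fold higher number from compound 2 to compound 3 (0.04 log units; within the scatter) and so leaves compound 2 and compound 3 indistinguishable. Among these compounds, the earlier step concerned only the group on the amide-type nitrogen, whereas this one is the first probe further out, on the aromatic ring of the benzyl group, and it shows that placing methoxy para to a large group, with its 2 heavy atoms and 1 hydrogen-bond acceptor, does not move the reading beyond the scatter. Nothing available explains why this exchange leaves the reading within the scatter.

A single substituent cannot show whether this place accepts other groups in the same way. A carboxylic acid, an amine or a longer chain such as butoxy at this place could give a quite different reading.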